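The compounds below may be only part of what the source reports. "The series", "measured", "known", "first", "only" and "open" are said of these compounds alone.

Compound 1 `CN1CCC[C@@H]1Cn1nc(Cc2ccc(O)cc2)c2ccccc2c1=O` gives 251 nM in an assay for binding affinity to Alpha-1A adrenergic receptor (Homo sapiens); on this read-out higher numbers stand for weaker inhibition and lower numbers for stronger inhibition; compound 2 `CN1CCC[C@@H]1Cn1nc(CCc2ccccc2)c2ccccc2c1=O` gives 200 nM, and the two numbers sit within the scatter of each other, since a 1.3-fold lower number from compound 1 to compound 2 (0.10 log units; within the scatter). Compound 3 `COC(=O)c1ccc(Cc2nn(C[C@H]3CCCN3C)c(=O)c3ccccc23)cc1` differs from compound 1 by methoxycarbonyl in place of hydroxy on an aromatic carbon. Within the data shown here, the only step measured so far that touches this position is the one between compound 1 and compound 2, which stayed within the scatter when the hydroxy was exchanged, so no effect beyond the scatter is expected here either, giving an expected step of a 1.2-fold higher number from compound 1 to compound 3 (0.08 log units; within the scatter). For compound 3 the estimate is 300 nM, with a range from 100 nM to 1000 nM.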

Compound 3, inhibition constant: > 1990 nM
Compound 3: no number, only a limit (the forecaster's own chance of this, stated with the estimate: 5%); middle value at least 6.6-fold (0.82 log units) from the limit.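

This position is not as tolerant as the earlier pair suggested: methoxycarbonyl in place of hydroxy on this aromatic carbon gives an at least 7.9-fold higher number from compound 1 to compound 3 (0.89 log units; beyond the scatter). Compound 3 has only a limit, not a number: the limit of > 1990 nM in this assay, at which 1 of the 3 values shown sits. So a change at this aromatic carbon can move the read-out beyond the scatter, which the step from compound 1 to compound 2 did not show.

Going by these compounds, it remains open whether the step comes from the hydroxy leaving or the methoxycarbonyl entering. A methoxy group, a carboxylic acid or an amine on the same aromatic carbon could help separate the two.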